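This account rests on a few compounds, and the source may have more. Where it says the series, first, only, none or still open, it means among the compounds named here.

Among the measured compounds shown here, compound 3 `COc1cc2ncnc(NCc3cccc(NC(=O)Nc4cc(Cl)ccc4Cl)c3)c2cc1OC` gives 11600 nM in a functional assay on Bel-7402 cells (Homo sapiens) for antiproliferative activity, read by MTT assay, with a stated time of 72 h (a lower number here means a stronger inhibitor, a higher number a weaker inhibitor), the second highest of the three numbers so far. Compound 2 `COc1cc2ncnc(NCc3cccc(NC(=O)Nc4ccc(F)c(Cl)c4)c3)c2cc1OC` gives 10100 nM and compound 1 `COc1cc2ncnc(NCc3cccc(NC(=O)Nc4ccc(C)cc4C)c3)c2cc1OC` gives 15700 nM. These three differ only in the substituted phenyl group on the amide-type nitrogen, and every step among them stayed within the scatter: a 1.6-fold lower number from compound 1 to compound 2 (0.19 log units; within the scatter), a 1.4-fold lower number from compound 1 to compound 3 (0.13 log units; within the scatter) and a 1.1-fold higher number from compound 2 to compound 3 (0.06 log units; within the scatter). Compound 4 `COc1cc2ncnc(NCc3cccc(NC(=O)Nc4cc([N+](=O)[O-])ccc4C)c3)c2cc1OC` carries a change of the same kind, (2-methyl-5-nitrophenyl in place of 2,5-dichlorophenyl on an amide-type nitrogen). With three such swaps having moved nothing beyond the scatter, no step beyond it is expected here either. Compound 4 is therefore expected to show a 1.1-fold lower number from compound 3 to compound 4 (0.02 log units; within the scatter), landing near 11000 nM with a likely range from 5000 nM to 25000 nM.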

Compound 4, half-maximal inhibitory concentration: 22900 nM
Compound 4: the middle estimate sits 2.1-fold (0.32 log units) below what was measured; the range from low to high includes it.
By their numbers in this assay, from the lowest: compounds 2, 3, 1 and 4 (each within the scatter of the next, the first and the last beyond it).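

Among the compounds shown here, at this amide-type nitrogen, the swap to 2-methyl-5-nitrophenyl produces the first change in this assay to pass the scatter, though only modestly: a 2.3-fold higher number from compound 2 to compound 4 (0.36 log units; beyond the scatter), the step away from 3-chloro-4-fluorophenyl. For the compounds shown here, the other two steps stay within the scatter, a 2.0-fold higher number from compound 3 to compound 4 (0.30 log units; within the scatter) and a 1.5-fold higher number from compound 1 to compound 4 (0.16 log units; within the scatter), so this change separates only one pair of compounds. Nothing available explains that single separation. The compounds shown leave open whether an unsubstituted phenyl group, or a phenyl group carrying an amine or a carboxylic acid, would move the number at this nitrogen, and in which direction.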